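Swapping Methyl for Fluoro: Expected Cytotoxicity of Compound 4

This account rests on a few compounds, and the source may have more. Where it says the series, first, only, none or still open, it means among the compounds named here.

Compound 1 `Cc1ccc(-c2nc3ccccc3s2)cc1NC(=O)c1cc([N+](=O)[O-])ccc1Cl` carries a methyl group and a 1,3-benzothiazol-2-yl group on the shared core. In an ADME assay on Raji cells (Homo sapiens) for cytotoxicity, with a stated time of 72 h (a higher number here means that more compound is needed for the effect, a lower number that less compound is needed), compound 1 gives > 14000 nM, a limit of the assay rather than a number. Compound 2 `O=C(Nc1cc(-c2nc3ccccc3s2)ccc1F)c1cc([N+](=O)[O-])ccc1Cl` differs by fluoro in place of methyl on an aromatic carbon. In this assay compound 2 gives > 25000 nM, again a limit. Compound 3 `Cc1ccc(-c2nc3ccccc3o2)cc1NC(=O)c1cc([N+](=O)[O-])ccc1Cl` differs from compound 1 by 1,3-benzoxazol-2-yl in place of 1,3-benzothiazol-2-yl on an aromatic carbon. In this assay compound 3 gives > 14000 nM, also a limit. The size of a step that the two limits leave unreadable from compound 1 to compound 2 cannot be read because the limit of > 14000 nM in this assay, at which 2 of the 3 values shown sit, and the limit of > 25000 nM in this assay, at which 1 of the 3 values shown sits, bound both ends.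

Compound 4 `O=C(Nc1cc(-c2nc3ccccc3o2)ccc1F)c1cc([N+](=O)[O-])ccc1Cl` differs from compound 3 by fluoro in place of methyl on an aromatic carbon. This is the same kind of change as between compound 1 and compound 2, the place differing only in being para to a 1,3-benzoxazol-2-yl group rather than a 1,3-benzothiazol-2-yl group. The step from compound 3 is expected to be a step that the limit leaves unreadable from compound 3 to compound 4. That expectation rests on compound 3 sitting at a limit > 14000 nM. Compound 4 is therefore estimated at 25000 nM, likely between 10000 nM and 60000 nM, and most probably reported only as a limit.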

Compound 4, half-maximal effective concentration: > 25000 nM
Compound 4 was reported as a limit; the forecaster's own chance of this, stated with the estimate: 85%; the middle value sits exactly at the limit.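

The steps from compound 3 to compound 4 and from compound 2 to compound 4 cannot be read, since all three compounds are reported only as limits. The compounds shown leave open whether swapping methyl for fluoro, or 1,3-benzothiazol-2-yl for 1,3-benzoxazol-2-yl, changes the concentration needed in this assay at all.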